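The source may report more compounds than this note shows. Statements on the series, on what has been measured and on what is new or still open speak of the compounds shown alone.

Among the measured compounds shown here, in a functional assay on KBVIN cells (Homo sapiens) for antiproliferative activity, read by sulforhodamine B assay, with a stated time of 3 days (a higher number here means that more compound is needed for the effect, a lower number that less compound is needed), compound 2 `CCCC1=C(OCC)C(CCC)(CCC)C(=O)/C(=C(O)\C=C\c2ccccc2)C1=O` gives 3.5 uM, the lower of the two numbers measured so far. Compound 1 `CCCC1=C(OCCC(C)C)C(CCC)(CCC)C(=O)/C(=C(O)\C=C\c2ccccc2)C1=O` gives 19.2 uM. Next in the series is compound 3 `CCCOC1=C(CCC)C(=O)/C(=C(O)/C=C/c2ccccc2)C(=O)C1(CCC)CCC`, which changes compound 2 from ethoxy to propoxy: methyl in place of hydrogen on a saturated chain carbon, two bonds along the chain from an oxygen on an unsaturated carbon.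

For the measured compounds named here, only one measured step bears on this place: a 5.5-fold lower number from compound 1 to compound 2 (0.74 log units; beyond the scatter), where hydrogen replaces isopropyl. Read in reverse, that step suggests the number in this assay rises as the chain grows at this place. Methyl is a smaller addition than isopropyl, so a rise well short of that step is expected, possibly not clear of the scatter. On these data alone, with just two measured compounds, the trend rests on a single pair and its shape along the chain is unknown. The estimate amounts to a 1.7-fold higher number from compound 2 to compound 3 (0.23 log units; within the scatter), an expected modest rise. For compound 3 the expected value is 6 uM, with an estimated range of 2.5 uM to 14 uM.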

Compound 3, concentration for half-maximal effect: 2.4 uM
Estimate against measurement, compound 3: 2.5-fold (0.40 log units) above; measured number below the stated range.
By their numbers in this assay, from the lowest: compounds 3 and 2 (each within the scatter of the next); then compound 1.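

In this assay, among the compounds shown here, the change from ethoxy to propoxy gives a 1.5-fold lower number from compound 2 to compound 3 (0.16 log units; within the scatter) and so shows no clear shift at this place, which the single earlier pair could not reveal: that pair left open whether any growth of the chain would raise the number. Methyl in place of isopropyl on the same saturated chain carbon instead gives an 8.0-fold lower number from compound 1 to compound 3 (0.90 log units; beyond the scatter) so among these three compounds the clear gap goes with the isopropyl group, while the single added methyl leaves the number within the scatter. Nothing available on these compounds accounts for this difference between methyl and isopropyl.

The point along the chain at which the number starts to climb remains unlocated, and a straight butoxy or pentyloxy chain would show whether length alone is enough or whether the branched end of compound 1 matters. Equally open, on these data alone, is how a shorter methoxy group, or a chain ending in a hydroxyl group or an amine, would read at this place on the shared core.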